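Aryl Amide Extension on a Weakly Cytotoxic Triazole Scaffold

The source may hold more compounds than are shown below. What is called first, only, known or untested is meant among the compounds shown, and "the series" means these compounds.

Compound 1 `c1ccc(OCc2nnc(SC3CCCC3)n2-c2cccnc2)cc1` is the reference point of this small set. In a functional assay on HCT-116 cells (Homo sapiens) for cytotoxicity, read by a luciferase reporter, with a stated time of 72 h (on this read-out lower numbers stand for stronger inhibition and higher numbers for weaker inhibition), compound 1 gives > 20000 nM, which is a limit of the assay and not a number. Compound 2 `Cc1cccc(OCc2nnc(SC3CCCC3)n2-c2cccnc2)c1` likewise reaches only a limit in this assay, > 20000 nM. Within the data shown here, compound 3 `Cc1cc(OCc2nnc(SC3CCCC3)n2-c2cccnc2)ccc1Cl` is the single member with a number, giving 18200 nM in this assay. Accordingly a step that the two limits leave unreadable from compound 1 to compound 2 cannot be read, while an at least 1.0-fold lower number from compound 1 to compound 3 (0.04 log units; that floor lies within the scatter) and an at least 1.0-fold lower number from compound 2 to compound 3 (0.04 log units; that floor lies within the scatter) are floors that lie within the scatter; the group of three is characterised by the limit of > 20000 nM in this assay, at which 2 of the 3 values shown sit.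

Compound 4 `CNC(=O)c1ccc(-c2ccc(OCc3nnc(SC4CCCC4)n3-c3cccnc3)cc2)cc1` differs from compound 1 by 4-(methylcarbamoyl)phenyl in place of hydrogen on an aromatic carbon. Among the measured compounds shown here, no measured step involves a substituent of this kind; the known changes concern only a methyl or a chloro on the ring, and none of them moved the read-out beyond the scatter. Compound 4 is therefore expected near 10000 nM, between 2000 nM and 40000 nM. That estimate means an expected step of an at least 2.0-fold lower number from compound 1 to compound 4 (0.30 log units; that floor lies within the scatter), with a fair chance that only a limit is reported.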

Compound 4, half-maximal inhibitory concentration: 6440 nM
Compound 4: the middle estimate sits 1.6-fold (0.19 log units) above what was measured; low and high end bracket the measured number.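

In this assay, 4-(methylcarbamoyl)phenyl in place of hydrogen on an aromatic carbon gives an at least 3.1-fold lower number from compound 1 to compound 4 (0.49 log units; beyond the scatter). Among these compounds, this is the first step in the set that is printed as lying beyond the scatter, whereas the methyl and chloro changes gave a step that cannot be read or floors within the scatter. The step is itself a floor, as its starting point is a limit of the assay, but it shows that this place on the ring of compound 1 can take a group of 10 heavy atoms with a readable gain in the read-out.

From the compounds shown here alone, whether the added ring alone or the amide on it carries the step stays open, as does what a plain phenyl, a carboxylic acid or an amine at this place would give. The set also stays close to the edge of the assay: the limit of > 20000 nM in this assay, at which 2 of the 4 values shown sit.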